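Methoxy in place of trifluoromethyl on the shared core

A few compounds are considered here, and "the series" means these few. Any claim that something is new, unique, unknown or untested is made for them only; others in the source may bear on it.

In a functional assay on HL-60 cells (Homo sapiens) for antiproliferative activity, read by MTT assay, with a stated time of 72 h (on this read-out higher numbers stand for weaker inhibition and lower numbers for stronger inhibition), compound 1 (`COc1cc(-c2nc(N(C)C)sc2-c2ccc3ccccc3c2)cc(OC)c1OC`) gives 2570 nM and compound 2 (`COc1cc(-c2nc(N(C)C)sc2-c2ccc(C)cc2)cc(OC)c1OC`) gives 3480 nM, with a 1.4-fold higher number from compound 1 to compound 2 (0.13 log units; within the scatter). Compound 3 (`COc1cc(-c2nc(N(C)C)sc2-c2ccc(C(F)(F)F)cc2)cc(OC)c1OC`) is reported only as a limit, > 10000 nM. Compound 4 (`COc1ccc(-c2sc(N(C)C)nc2-c2cc(OC)c(OC)c(OC)c2)cc1`) has methoxy in place of trifluoromethyl on an aromatic carbon. Going by the values given here, the steps that bear on this are an at least 2.8-fold higher number from compound 2 to compound 3 (0.45 log units; beyond the scatter) and an at least 3.8-fold higher number from compound 1 to compound 3 (0.59 log units; beyond the scatter), both of which introduce the 4-(trifluoromethyl)phenyl group that compound 4 gives up. Among the compounds with values here, no measured compound carries methoxy, so the expectation rests on compound 2 at 3480 nM. The expected change, toward stronger inhibition and beyond the scatter, is an at least 10-fold lower number from compound 3 to compound 4 (1.00 log units; beyond the scatter). Compound 4 is estimated at 1000 nM, with an expected range of 150 nM to 5000 nM.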

Compound 4, half-maximal inhibitory concentration: 1890 nM
For compound 4 the middle estimate is 1.9-fold (0.28 log units) below the measured one, and the stated range covers the measured number.
By their numbers in this assay, from the lowest: compounds 4, 1 and 2 (each within the scatter of the next). At a limit, above all of these: compound 3.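

In this assay, the move from 4-(trifluoromethyl)phenyl to 4-methoxyphenyl, para to a large group, gives a clear gain (with an at least 5.2-fold lower number from compound 3 to compound 4 (0.72 log units; beyond the scatter)). On these data alone, compound 3 stands only at a limit, so the full size of this step stays unknown: the limit of > 10000 nM in this assay, at which 1 of the 4 values shown sits. Methoxy does not separate from methyl (with a 1.8-fold lower number from compound 2 to compound 4 (0.27 log units; within the scatter)) or from naphthalen-2-yl (with a 1.4-fold lower number from compound 1 to compound 4 (0.13 log units; within the scatter)), which leaves trifluoromethyl as the only group apart from the others in this set.

As far as these compounds go, whether chlorine, an amine or a carboxylic acid at this place would fall with methoxy or with trifluoromethyl remains open.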